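Swapping trifluoromethyl for fluoro on the aryl amide

The source may hold more compounds than are shown below. What is called first, only, known or untested is meant among the compounds shown, and "the series" means these compounds.

Measured so far:
compound 1, `Cc1nc(C(NC(=O)C(=O)Nc2ccc(C(F)(F)F)cc2)C2CCCCN2)sc1CO`: > 75500 nM
compound 2, `Cc1nc(C(NC(=O)C(=O)Nc2ccc(Cl)cc2)C2CCNCC2)sc1CO`: > 81000 nM

In an ADME assay on MT2 cells (Homo sapiens) for cytotoxicity, read by XTT assay, with a stated time of 4 days (a lower number here means that less compound is tolerated, a higher number that more compound is tolerated), compound 1 gives > 75500 nM, which is a limit of the assay rather than a measured number. Compound 2 gives > 81000 nM in this assay, again a limit. Compound 1 therefore stands at the limit of > 75500 nM in this assay, at which 1 of the 2 values shown sits, and compound 2 at the limit of > 81000 nM in this assay, at which 1 of the 2 values shown sits; on the numbers shown, neither compound reaches a cytotoxic concentration within the tested range.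

Compound 3, `Cc1nc(C(NC(=O)C(=O)Nc2ccc(F)cc2)C2CCCCN2)sc1CO`, is not yet measured. It differs from compound 1 by fluoro in place of trifluoromethyl on an aromatic carbon. Within the data shown here, no step between measured compounds is available to guide the expectation. Given that compound 1 sits at the limit of > 75500 nM in this assay, at which 1 of the 2 values shown sits, no step beyond the scatter is expected, and the step that the limit leaves unreadable from compound 1 to compound 3 is expected to be small. Compound 3 is estimated at 80000 nM, with a range from 30000 nM to 200000 nM, and is expected most likely to return only a limit again.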

Compound 3, half-maximal cytotoxic concentration: > 113000 nM
Compound 3 ended at the assay's limit; the forecaster's own chance of this, stated with the estimate: 80%; middle value at least 1.4-fold (0.14 log units) from the limit.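

Compound 3 gives > 113000 nM in this assay, which is a limit and not a number. Among these compounds, compound 1 also stands at a limit, so no step from compound 1 to compound 3 can be read. The concentration at which any compound shown harms the cells, and whether fluoro in place of trifluoromethyl changes it, remain open.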